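The source may hold more compounds than are shown below. What is called first, only, known or untested is meant among the compounds shown, and "the series" means these compounds.

Compound 1, `CNCC(=O)N(C)CC(=O)Nc1nc2ccc(OC(F)(F)F)cc2s1`, in an ADME assay for pharmacokinetics, read by LC-MS, in simulated intestinal fluid, tested at 0.01 mg/mL (a lower number here means that the compound disappears faster, a higher number that the compound lasts longer), gives < 1 h, a limit of the assay.
Compound 2, `CC(C)(NC(=O)CN)C(=O)Nc1nc2ccc(OC(F)(F)F)cc2s1`, gives < 1 h in this assay, likewise a limit.

Both values sit at the same limit, as the limit of < 1 h in this assay, at which 2 of the 2 values shown sit, shows, so the step that the two limits leave unreadable from compound 1 to compound 2 cannot be read. Compound 3, `CC(C)(C)NCC(=O)NC(C)(C)C(=O)Nc1nc2ccc(OC(F)(F)F)cc2s1`, differs from compound 2 by tert-butyl in place of hydrogen on an amine nitrogen. Among the measured compounds shown here, no measured step bears on this change, and the size of the step from compound 2 to compound 3 remains a guess. The step is expected to be an at least 1.5-fold higher number from compound 2 to compound 3 (0.17 log units; that floor lies within the scatter). Compound 3 is estimated at 1.5 h, ranging from 0.5 h to 4 h.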

Compound 3, half-life: > 4 h
Compound 3: a limit, no number (the forecaster's own chance of this, stated with the estimate: 40%); at least 2.6-fold (0.42 log units) between middle value and limit.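

Tert-butyl in place of hydrogen on an amine nitrogen gives an at least 4.0-fold higher number from compound 2 to compound 3 (0.60 log units; beyond the scatter) in this assay. Compound 3 gives > 4 h, a limit of the assay and not a number, so only the minimum size of this step is known. Unlike the earlier pair, whose values shared one limit, this pair shows that a change at this amine nitrogen can produce a readable difference in half-life.

On these data alone, what causes the rise remains open. So does whether isopropyl or cyclopropyl on the same amine nitrogen would give a similar step.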